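A few compounds are considered here, and "the series" means these few. Any claim that something is new, unique, unknown or untested is made for them only; others in the source may bear on it.

Measured compounds:
compound 1 `CC(C)NCCS(=O)(=O)NC(=O)c1ccc(Nc2nc(NC3(c4ccc(Cl)cc4)CC3)nc(OCC(F)(F)F)n2)cc1`: 89%
compound 2 `O=C(NS(=O)(=O)C1CC1)c1ccc(Nc2nc(NC3(c4ccc(Cl)cc4)CC3)nc(OCC(F)(F)F)n2)cc1`: 100%
compound 3 `CS(=O)(=O)NC(=O)c1ccc(Nc2nc(NC3(c4ccc(Cl)cc4)CC3)nc(OCC(F)(F)F)n2)cc1`: 100%

In an ADME assay on microsomes from liver (Homo sapiens) for metabolic stability, with a stated time of 10 min (a higher number here means that more of the compound is left, a lower number that less of the compound is left), compound 3 stands together with compound 2 at the top of the three numbers (no change at the digits printed from compound 2 to compound 3 (within the scatter)), while compound 1 sits lower (a number 11 percentage points higher from compound 1 to compound 3 (beyond the scatter)).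

Compound 4 `CN(C)S(=O)(=O)NC(=O)c1ccc(Nc2nc(NC3(c4ccc(Cl)cc4)CC3)nc(OCC(F)(F)F)n2)cc1` differs from compound 3 by dimethylamino in place of methyl on a sulfonyl sulfur. The step that bears most on this is the exchange on the same sulfonyl sulfur, which gave no change at the digits printed from compound 2 to compound 3 (within the scatter). The other two steps, a number 11 percentage points higher from compound 1 to compound 2 (beyond the scatter) and a number 11 percentage points higher from compound 1 to compound 3 (beyond the scatter), both remove the longer chain and were only modest. No step beyond the scatter is therefore expected for compound 4 in this assay: a number 5 percentage points lower from compound 3 to compound 4 (within the scatter). For compound 4 the estimate is 95%, with a range from 80% to 100%.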

Compound 4, percent of the compound remaining: 86%
The estimate for compound 4 lay 9 percentage points above the measured number, within the range that was stated.
By their numbers in this assay, from the lowest: compounds 4 and 1 (each within the scatter of the next); then compounds 2 and 3 (each within the scatter of the next).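

In this assay the group on the sulfonyl sulfur matters even without the 2-(isopropylamino)ethyl chain: a number 14 percentage points lower from compound 3 to compound 4 (beyond the scatter) and a number 14 percentage points lower from compound 2 to compound 4 (beyond the scatter), although methyl and cyclopropyl had been level. Losing that chain therefore does not by itself secure the top values, since dimethylamino stays within the scatter of it: a number 3 percentage points lower from compound 1 to compound 4 (within the scatter). No measured finding accounts for this drop. As far as these compounds go, whether it follows the nitrogen on the sulfur or the two methyl groups stays open. An ethyl or a plain amino group on the same sulfur would separate the two.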